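This account rests on a few compounds, and the source may have more. Where it says the series, first, only, none or still open, it means among the compounds named here.

In a functional assay on A549 cells (Homo sapiens) for antiproliferative activity, read by MTT assay, with a stated time of 72 h (on this read-out higher numbers stand for weaker inhibition and lower numbers for stronger inhibition), three compounds sharing one core have been measured. Compound 1 `Cc1ccc(-c2noc(CCCCCCC(=O)NO)n2)cc1` gives 5810 nM, and compound 3 `O=C(CCCCCCc1nc(-c2cccc([N+](=O)[O-])c2)no1)NO` gives 10800 nM, a value within the scatter of compound 1. Within the data shown here, compound 2 `O=C(CCCCCCc1nc(-c2ccc(C(F)(F)F)cc2)no1)NO` gives 14000 nM, the one value beyond the scatter from compound 1. Among the measured compounds shown here, that comparison is the only measured single-place step: trifluoromethyl in place of methyl on an aromatic carbon gave a 2.4-fold higher number from compound 1 to compound 2 (0.38 log units; beyond the scatter), a modest size.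

Compound 4 `O=C(CCCCCCc1nc(-c2cccnc2)no1)NO` carries pyridin-3-yl in place of 4-methylphenyl on an aromatic carbon of the core: pyridin-3-yl in place of 4-methylphenyl on an aromatic carbon. For the measured compounds named here, no measured step replaces the carbon-only ring with one holding a ring nitrogen, so the step to compound 2 bears on this change only indirectly. It suggests that a change at this end of compound 1 need not be large, and a number somewhat higher is the likelier direction. The step expected in this assay is a 1.5-fold higher number from compound 1 to compound 4 (0.17 log units; within the scatter), an estimate within the scatter. For compound 4 the estimated value is 8500 nM, with an expected range from 3500 nM to 20000 nM.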

Compound 4, half-maximal inhibitory concentration: 5340 nM
Beside the measured number, compound 4's estimate is 1.6-fold (0.20 log units) above it; the range from low to high includes it.
By their numbers in this assay, from the lowest: compounds 4, 1, 3 and 2 (each within the scatter of the next, the first and the last beyond it).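

In this assay, pyridin-3-yl in place of 4-methylphenyl gives a 1.1-fold lower number from compound 1 to compound 4 (0.04 log units; within the scatter) and so lies within the scatter, which shows that the aromatic carbon of the shared core can carry a six-membered aromatic ring with a ring nitrogen as well as a carbon-only ring. The earlier single-place step, a 2.4-fold higher number from compound 1 to compound 2 (0.38 log units; beyond the scatter), changed only the group on the ring and lay beyond the scatter, whereas this step replaces the whole 4-methylphenyl group and adds a hydrogen-bond acceptor without a change that can be told from the scatter. No evidence at hand accounts for this result.

The compounds shown leave open whether pyridin-2-yl or pyridin-4-yl would behave like pyridin-3-yl here, and whether a phenyl ring bearing an amine or a carboxylic acid would stay within the scatter of compound 1. They also leave open what a longer chain would do.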